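Halogen swap on the aryl piperazine of a xanthine sulfonamide

The compounds below may be only part of what the source reports. "The series", "measured", "known", "first", "only" and "open" are said of these compounds alone.

Compound 3 `CCCn1c(=O)[nH]c2nc(-c3ccc(S(=O)(=O)N4CCN(c5cccc(Cl)c5)CC4)cc3)[nH]c2c1=O` carries a 3-chlorophenyl group on the piperazine nitrogen of the shared core. In an assay on CHO cells for displacement of a labelled ligand from adenosine receptor A3 (Homo sapiens), read by scintillation counting, with a stated time of 45 min, in the presence of a further agent that is not named here (on this read-out higher numbers stand for weaker inhibition and lower numbers for stronger inhibition), compound 3 gives 53.5 nM, the lowest number among those shown. Compound 2 `CCCn1c(=O)[nH]c2nc(-c3ccc(S(=O)(=O)N(C)C)cc3)[nH]c2c1=O`, which has a dimethylamino sulfonamide instead, gives 1220 nM in this assay. Compound 1 `CCCn1c(=O)[nH]c2nc(-c3ccc(S(=O)(=O)N4CCN(c5ccc(F)cc5)CC4)cc3)[nH]c2c1=O`, bearing a 4-fluorophenyl group, reaches only a limit of the assay, > 1000 nM, so the limit of > 1000 nM in this assay, at which 1 of the 3 values shown sits, applies to it.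

Compound 4 `CCCn1c(=O)[nH]c2nc(-c3ccc(S(=O)(=O)N4CCN(c5cccc(F)c5)CC4)cc3)[nH]c2c1=O` differs from compound 3 by fluoro in place of chloro on an aromatic carbon. Going by the values given here, the only measured step that touches this part of the molecule is an at least 18-fold lower number from compound 1 to compound 3 (1.27 log units; beyond the scatter); it changes both the halogen and its position at once, so it does not isolate the effect of chloro against fluoro. Among the compounds with values here, no measured pair separates the two halogens at the same position.

With so little to go on, compound 4 is expected to give a somewhat higher number than compound 3, a step of a 2.4-fold higher number from compound 3 to compound 4 (0.39 log units; beyond the scatter), since the shift from compound 1 to compound 3 shows that this region matters. Compound 4 is therefore estimated at 130 nM, with a range from 40 nM to 450 nM.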

Compound 4, inhibition constant: > 1000 nM
Compound 4: no number, only a limit (the forecaster's own chance of this, stated with the estimate: 5%); middle value at least 7.6-fold (0.88 log units) away from the limit.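

Replacing chloro with fluoro on the same aromatic carbon, with nothing else altered, gives an at least 18-fold higher number from compound 3 to compound 4 (1.27 log units; beyond the scatter) in this assay. The earlier step changed the halogen and its position at once, whereas this pair holds the position fixed and shows that, with this core and sulfonamide, the 3-chlorophenyl group and the 3-fluorophenyl group are far from interchangeable. A halogen at this position is therefore not enough on its own to give the low number of compound 3; the value of compound 4 is a limit and not a number, and the step from compound 1 to compound 4 cannot be read, so a fluoro group on these two positions cannot be ranked: the limit of > 1000 nM in this assay, at which 2 of the 4 values shown sit.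

The compounds shown leave open whether bromo, methyl or methoxy on the same aromatic carbon would keep the number of compound 3 or lose it as fluoro does, and how a plain phenyl group on the piperazine nitrogen would compare. Going by these compounds alone, they also leave open whether chloro depends on its place, since no compound here carries chloro on any other carbon of that ring.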